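From 4-bromophenyl to 3-fluorophenyl on the urea end

This account rests on a few compounds, and the source may have more. Where it says the series, first, only, none or still open, it means among the compounds named here.

In a functional assay on NCI-H460 cells (Homo sapiens) for inhibition, read by MTT assay, with a stated time of 72 h (on this read-out higher numbers stand for weaker inhibition and lower numbers for stronger inhibition), compound 3 (`COc1cc(NC(C)CCCNC(=O)NNC(=O)Nc2ccc(Br)cc2)c2ncccc2c1`) gives 27000 nM and compound 2 (`COc1cc(NC(C)CCCNC(=O)Nc2ccc(F)cc2)c2ncccc2c1`) gives 26000 nM so these two sit within the usual scatter of each other. For compound 1 (`COc1cc(NC(C)CCCNC(=O)NNC(=O)Nc2ccc(F)cc2)c2ncccc2c1`) this assay gives only a limit of > 100000 nM and no exact number. Compound 4 (`COc1cc(NC(C)CCCNC(=O)NNC(=O)Nc2cccc(F)c2)c2ncccc2c1`) carries 3-fluorophenyl in place of 4-bromophenyl on an amide-type nitrogen. The nearest guide is an at least 3.7-fold lower number from compound 1 to compound 3 (0.56 log units; beyond the scatter) with bromo in place of fluoro on an aromatic carbon. Going by the values given here, no measured compound shows 3-fluorophenyl, so the guide is only partial. Returning to fluoro, a modest weakening is expected, estimated as a 2.0-fold higher number from compound 3 to compound 4 (0.31 log units; beyond the scatter) in this assay overall. For compound 4 the expected value is 55000 nM with an estimated range from 22000 nM to 100000 nM for now.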

Compound 4, half-maximal inhibitory concentration: 50000 nM
For compound 4 the middle estimate is 1.1-fold (0.04 log units) above the measured one; the measured number falls inside the stated range.
By their numbers in this assay, from the lowest: compounds 2, 3 and 4 (each within the scatter of the next). At a limit, above all of these: compound 1.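

A fluorophenyl group on this amide-type nitrogen can still give an exact number in this assay, and exchanging 4-bromophenyl for 3-fluorophenyl gives a 1.9-fold higher number from compound 3 to compound 4 (0.27 log units; within the scatter). The comparison with the shorter 4-fluorophenyl compound gives a 1.9-fold higher number from compound 2 to compound 4 (0.28 log units; within the scatter), so neither change separates these compounds. Placing fluoro as in 3-fluorophenyl rather than 4-fluorophenyl gives an at least 2.0-fold lower number from compound 1 to compound 4 (0.30 log units; that floor lies within the scatter), so the effect of this move stays unresolved, and compound 1 remains a limit: the limit of > 100000 nM in this assay, at which 1 of the 4 values shown sits.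

From the compounds shown here alone, whether a plain phenyl, a 3-bromophenyl or a 4-aminophenyl on this nitrogen would give a number beyond the scatter of these values stays open.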